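This account rests on a few compounds, and the source may have more. Where it says the series, first, only, none or still open, it means among the compounds named here.

Three compounds share one core and differ only in the group on one phenyl ring. Compound 1 `Fc1ccc(-c2nc3sc(Cc4ccc(Cl)cc4)nn3c2Br)cc1` carries a fluoro there, compound 2 `Clc1ccc(Cc2nn3c(Br)c(-c4ccc(Cl)cc4)nc3s2)cc1` a chloro, and compound 3 `O=[N+]([O-])c1ccc(-c2nc3sc(Cc4ccc(Cl)cc4)nn3c2Br)cc1` a nitro. In a functional assay on L1210 cells (Mus musculus) for cytotoxicity, with a stated time of 48 h (on this read-out lower numbers stand for stronger inhibition and higher numbers for weaker inhibition), compound 1 gives only a limit of the assay, > 250000 nM. Compound 2 likewise gives only a limit, > 250000 nM. Compound 3 gives a number, 94000 nM. Compound 2 therefore stands at the limit of > 250000 nM in this assay, at which 2 of the 3 values shown sit. The step from fluoro to chloro, a step that the two limits leave unreadable from compound 1 to compound 2, cannot be read, whereas an at least 2.6-fold lower number from compound 1 to compound 3 (0.42 log units; beyond the scatter) and an at least 2.6-fold lower number from compound 2 to compound 3 (0.42 log units; beyond the scatter) are readable.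

Compound 4 `O=Cc1c(-c2ccc(Cl)cc2)nc2sc(Cc3ccc(Cl)cc3)nn12` keeps the chloro of compound 2 and changes a different place: formyl in place of bromo on an aromatic carbon. Among the measured compounds shown here, none of the measured steps touches this place, so none bears directly on the change. Compound 4 is therefore expected to remain near the limit seen for compound 2, and the step of an at least 1.6-fold lower number from compound 2 to compound 4 (0.22 log units; that floor lies within the scatter) is expected to stay within the scatter. The estimate for compound 4 in this assay is 150000 nM, ranging from 30000 nM to 600000 nM.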

Compound 4, half-maximal inhibitory concentration: 15000 nM
Estimate against measurement, compound 4: 10-fold (1.00 log units) above; the whole stated range lies above it.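

The earlier compounds shown here differed only in the group on one phenyl ring, so they said nothing about the aromatic carbon next to the ring nitrogen. This place turns out to matter in this assay: putting formyl there in place of bromo gives an at least 16-fold lower number from compound 2 to compound 4 (1.22 log units; beyond the scatter). That size is only a floor, since compound 2 has no exact number, just a limit of the assay: the limit of > 250000 nM in this assay, at which 2 of the 4 values shown sit.

Going by these compounds, a single pair cannot separate what formyl adds from what the loss of bromo removes, so it remains open whether a plain hydrogen, a carboxylic acid or an amine at this place would read the same way. On these data alone, it is also open whether formyl would have a comparable effect with fluoro or nitro on the phenyl ring, as in compound 1 or compound 3.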